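The source may report more compounds than this note shows. Statements on the series, on what has been measured and on what is new or still open speak of the compounds shown alone.

In an ADME assay on HEK293 cells (Homo sapiens) for cytotoxicity, read by MTT assay, with a stated time of 48 h (on this read-out lower numbers stand for stronger inhibition and higher numbers for weaker inhibition), compound 1 `Cc1ccc(/C=C2/S/C(=N/c3ccccc3)N(Cc3ccncc3)C2=O)cc1` gives 49500 nM. Compound 2 `O=C1/C(=C\c2ccc(Cl)cc2)S/C(=N/c2ccccc2)N1Cc1ccncc1` gives 42300 nM, which makes a 1.2-fold lower number from compound 1 to compound 2 (0.07 log units; within the scatter), so these two sit level. Compound 3 `O=C1/C(=C\c2ccc(O)c(O)c2)S/C(=N/c2ccccc2)N1Cc1ccncc1` stands apart at 230000 nM, and compound 1 therefore lies toward the low end of the three numbers.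

Compound 4 `COc1ccc(/C=C2/S/C(=N/c3ccccc3)N(Cc3ccncc3)C2=O)cc1OC` keeps the core of compound 1 and changes one group: 3,4-dimethoxyphenyl in place of 4-methylphenyl on a double-bonded chain carbon bound to a double-bonded ring carbon. In words, 3,4-dimethoxyphenyl comes in place of 4-methylphenyl.

Going by the values given here, no measured compound carries this group, so the nearest guide is the other change made at this place. Putting 3,4-dihydroxyphenyl there gave a 4.6-fold higher number from compound 1 to compound 3 (0.67 log units; beyond the scatter) and also a 5.4-fold higher number from compound 2 to compound 3 (0.74 log units; beyond the scatter), both modest steps upward. Replacing methyl with chloro gave no step beyond the scatter. With only these cases to go on, a small upward move is expected, smaller than the steps to compound 3 and possibly within the scatter. The expected step is a 1.4-fold higher number from compound 1 to compound 4 (0.15 log units; within the scatter). For compound 4 the estimated value is 70000 nM, with an expected range from 30000 nM to 170000 nM.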

Compound 4, half-maximal inhibitory concentration: 171000 nM
Beside the measured number, compound 4's estimate is 2.4-fold (0.39 log units) below it, outside the stated range (above it).
By their numbers in this assay, from the lowest: compounds 2 and 1 (each within the scatter of the next); then compounds 4 and 3 (each within the scatter of the next).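

Compound 4 shows that a rise at this place does not depend on hydroxyl groups. In this assay, swapping the 3,4-dihydroxyphenyl group for 3,4-dimethoxyphenyl gives a 1.3-fold lower number from compound 3 to compound 4 (0.13 log units; within the scatter), so these two compounds sit level, while the 3,4-dimethoxyphenyl group still reads higher than the groups carrying one substituent, with a 3.5-fold higher number from compound 1 to compound 4 (0.54 log units; beyond the scatter) and a 4.0-fold higher number from compound 2 to compound 4 (0.61 log units; beyond the scatter). No measurement on hand explains why this group shifts the number upward.

As far as these compounds go, whether both oxygen-bearing groups are needed remains open, since a phenyl ring with a single methoxy group would separate the effect of one from that of two. It is also unknown how an amine or a carboxylic acid on this phenyl ring would read in this assay.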